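Shortening an Ethoxy Group to Methoxy on the Benzyl Ring

The source may report more compounds than this note shows. Statements on the series, on what has been measured and on what is new or still open speak of the compounds shown alone.

Compound 1 `CCCCCCN1CCC(C(=O)Nc2cc(Cl)c(N)cc2OC)CC1` gives in a functional assay on the whole organism for antagonist activity, with Mus musculus as the target (a higher number here means that more compound is needed for the effect, a lower number that less compound is needed), only a limit, > 10 mg/kg.
Compound 2 `COc1cc(N)c(Cl)cc1NC(=O)C1CCN(C2CCCC2)CC1` likewise gives in this assay only a limit, > 10 mg/kg.
Compound 3 `CCOc1ccc(CN2CCC(C(=O)Nc3cc(Cl)c(N)cc3OC)CC2)cc1` gives in this assay 6.3 mg/kg.

Among the compounds with values here, compound 3 thus holds the only real number of the three; the other two results are limits, as the limit of > 10 mg/kg in this assay, at which 2 of the 3 values shown sit, shows. Compound 4 `COc1ccc(CN2CCC(C(=O)Nc3cc(Cl)c(N)cc3OC)CC2)cc1` differs from compound 3 by hydrogen in place of methyl on a saturated chain carbon bound to an oxygen on an aromatic ring, ethoxy becoming methoxy. Within the data shown here, no measured step touches that position. The step of an at least 1.5-fold lower number from compound 1 to compound 3 (0.20 log units; that floor lies within the scatter) exchanged the whole group on the ring nitrogen, and a step that the two limits leave unreadable from compound 1 to compound 2 cannot be read, so neither bears directly on this small change. The step of a 1.0-fold higher number from compound 3 to compound 4 (0.01 log units; within the scatter) is expected to stay within the scatter. Compound 4 is therefore estimated at 6.5 mg/kg, between 3 mg/kg and 14 mg/kg.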

Compound 4, dose for half-maximal effect: 0.9 mg/kg
Compound 4: middle estimate off by 7.2-fold (0.86 log units), on the high side, and the stated range ends above it.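

In this assay, the ethoxy to methoxy change alone gives a 7.0-fold lower number from compound 3 to compound 4 (0.85 log units; beyond the scatter), so this position responds to the loss of a single methyl. The 4-methoxybenzyl group also stands well clear of the cyclopentyl and hexyl groups on the ring nitrogen, with an at least 11-fold lower number from compound 2 to compound 4 (1.04 log units; beyond the scatter) and an at least 11-fold lower number from compound 1 to compound 4 (1.04 log units; beyond the scatter). Both of these sizes are only floors, because each starts from a limit: the limit of > 10 mg/kg in this assay, at which 2 of the 4 values shown sit.

From the compounds shown here alone, whether a hydroxyl group or a chlorine in place of the methoxy would extend or reverse the step stays open. The compounds shown also give no reason for the step.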